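Fluoro added to the chlorophenyl ring of compound 2

The compounds below may be only part of what the source reports. "The series", "measured", "known", "first", "only" and "open" are said of these compounds alone.

Compound 2 `Cc1noc(NC(=O)N2CCC3(CC2)CC(c2cccc(Cl)c2)C3)c1C` is the anchor for this step. In a functional assay on the whole organism for inhibition, with Rattus norvegicus as the target, with a stated time of 3 h, at a dose of 3 mg/kg by the oral route (a lower number here means that less compound is needed, a higher number that more compound is needed for the effect), compound 2 gives 1 mg/kg. Its nearest neighbour is compound 1 `Cc1noc(NC(=O)N2CCC3(CC2)CC(c2cccc(OC(F)(F)F)c2)C3)c1C`, which in this assay gives 1 mg/kg; the step of no change at the digits printed from compound 1 to compound 2 (within the scatter) shows that chloro in place of trifluoromethoxy on an aromatic carbon leaves the read-out where it was, within the scatter. Compound 2 therefore stands level with compound 1 at the digits shown.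

The next compound is compound 3 `Cc1noc(NC(=O)N2CCC3(CC2)CC(c2ccc(F)c(Cl)c2)C3)c1C`. It differs from compound 2 by fluoro in place of hydrogen on an aromatic carbon, taking 3-chlorophenyl to 3-chloro-4-fluorophenyl. For the measured compounds named here, no measured step covers a fluoro added to this ring; the only step in hand, no change at the digits printed from compound 1 to compound 2 (within the scatter), concerns a different group on the same ring and was flat. That step gives no ground to expect a move here, and the change is confined to that ring. The expected step of no change at the digits printed from compound 2 to compound 3 (within the scatter) is none beyond the scatter. Compound 3 is estimated at 1 mg/kg in this assay, with a range from 0.5 mg/kg to 3 mg/kg.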

Compound 3, minimum effective dose: 0.3 mg/kg
The estimate for compound 3 lay 3.3-fold (0.52 log units) above the measured number; measured number below the stated range.
By their numbers in this assay, from the lowest: compound 3; then compounds 1 and 2 (each within the scatter of the next).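

In this assay, a 3.3-fold lower number from compound 2 to compound 3 (0.52 log units; beyond the scatter) shows that this ring can move the minimum effective dose beyond the scatter, which the earlier change on the same ring, no change at the digits printed from compound 1 to compound 2 (within the scatter), did not show. The change is small, a single fluoro with no ring and no net charge, on an aromatic carbon ortho to the chloro group and para to a large group, so even one added heavy atom at this place is enough to shift the read-out. Nothing at hand bears on why the number falls with this fluoro.

On these data alone, it remains open whether the shift is specific to fluoro or would also follow from another small group at this place, such as a methyl, a methoxy or a nitrile, or from a second chloro. As far as these compounds go, it is equally open whether the shift depends on the chloro group already on the ring, and the 3-trifluoromethoxy-4-fluorophenyl analogue of compound 1 would test this directly.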